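The compounds below may be only part of what the source reports. "The series", "measured", "known", "first", "only" and "open" are said of these compounds alone.

Measured compounds:

compound 1, `CC(C)Sc1nc(O)cc(C(C)c2ccccc2)n1`: > 200000 nM
compound 2, `CCC(c1ccccc1)c1cc(O)nc(SC(C)C)n1`: > 200000 nM
compound 3, `CC(c1cc(O)nc(SC2CCCCC2)n1)c1cccc2ccccc12`: 45000 nM

Within the data shown here, in a functional assay on MT4 cells (Homo sapiens) for cytotoxicity (a higher number here means that more compound is tolerated, a lower number that less compound is tolerated), compound 1 reaches only a limit, and compound 2 likewise; compound 3 is the one compound of the three with a number. Compound 2 differs from compound 1 by methyl in place of hydrogen on a saturated chain carbon, two bonds along the chain from two aromatic carbons. The step that the two limits leave unreadable from compound 1 to compound 2 cannot be read because the limit of > 200000 nM in this assay, at which 2 of the 3 values shown sit, holds both values. How compound 3 differs from compound 1 is not broken down here; the two cores differ in more than one place.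

Compound 4, `CCC(c1cc(O)nc(SC2CCCCC2)n1)c1cccc2ccccc12`, is not yet measured. Among the measured compounds shown here, it differs from compound 3 by methyl in place of hydrogen on a saturated chain carbon, two bonds along the chain from two aromatic carbons, the same change as the one from compound 1 to compound 2, at the same place. Since the earlier step gives no readable size, the expectation for compound 4 rests mainly on compound 3 and its value 45000 nM, with the change taken to move it little. Compound 4 is therefore expected to show a step of about a 1.1-fold lower number from compound 3 to compound 4 (0.05 log units; within the scatter) in this assay. The estimate for compound 4 is 40000 nM, with a likely range from 15000 nM to 120000 nM.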

Compound 4, half-maximal cytotoxic concentration: 23400 nM
Estimate against measurement, compound 4: 1.7-fold (0.23 log units) above; the measured number falls inside the stated range.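

In this assay, methyl in place of hydrogen on the saturated chain carbon gives a 1.9-fold lower number from compound 3 to compound 4 (0.28 log units; within the scatter), so on this core compound 3 and compound 4 cannot be told apart. On the core of compound 1 the same change cannot be read, because compound 1 and compound 2 both stand at a limit and neither gives a number: the limit of > 200000 nM in this assay, at which 2 of the 4 values shown sit. The series therefore offers one readable step on one core, which shows that the change stays within the scatter there but does not show that it behaves alike on both cores, and so gives no evidence that its size carries from one to the other.

The compounds shown leave open what a longer chain, such as propyl, or an amine on that same saturated chain carbon would give in this assay. They also leave open how the change would read on the core of compound 1 if its compounds gave numbers rather than limits.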